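Hydrogen in place of isopropyl on compound 1

This account rests on a few compounds, and the source may have more. Where it says the series, first, only, none or still open, it means among the compounds named here.

Of the compounds shown here, three sharing one core have been tested in a functional assay on K562 cells (Homo sapiens) for antiproliferative activity, read by CCK-8 assay, with a stated time of 72 h; a higher number here means a weaker inhibitor of growth, a lower number a stronger inhibitor of growth. Compound 1 (`CCC1C(=O)N(C)c2cnc(-n3ccc4cc(C(=O)NC(C)C)ccc43)nc2N1c1ccn(C)n1`) gives 8910 nM. Compound 3 (`CCC1C(=O)N(C)c2cnc(Nc3ccc(S(=O)(=O)NCCCO)cc3)nc2N1c1ccn(C)n1`) gives 13400 nM, which lies within the scatter of the value for compound 1, so the two cannot be ranked. Compound 2 (`CCC1C(=O)N(C)c2cnc(Nc3ccc(S(N)(=O)=O)cc3)nc2N1c1ccn(C)n1`) is recorded as "not active" (no number reported). Compound 1 therefore stands level with compound 3, and both are weak inhibitors of growth on these numbers.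

Compound 4 (`CCC1C(=O)N(C)c2cnc(-n3ccc4cc(C(N)=O)ccc43)nc2N1c1ccn(C)n1`) keeps the core of compound 1 and carries hydrogen in place of isopropyl on an amide-type nitrogen, turning isopropylcarbamoyl into carbamoyl (hydrogen in place of isopropyl on an amide-type nitrogen). For the measured compounds named here, no two measured compounds differ in one place only, so no measured step shows what this change does. The expectation therefore starts from compound 1 at 8910 nM and assumes no shift beyond the scatter in this assay, with a wide margin on either side. The expected change is a 1.1-fold higher number from compound 1 to compound 4 (0.05 log units; within the scatter), an estimate that stays within the scatter. A result without a number, as for compound 2, also remains possible. In this assay the estimate for compound 4 is 10000 nM, expected to fall between 3500 nM and 30000 nM.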

Compound 4, concentration for 50% growth inhibition: 31300 nM
For compound 4 the middle estimate is 3.1-fold (0.50 log units) below the measured one; the measured number lies above the stated range.
By their numbers in this assay, from the lowest: compounds 1 and 3 (each within the scatter of the next); then compound 4.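

In this assay, replacing the isopropyl on the amide-type nitrogen with hydrogen, which turns isopropylcarbamoyl into carbamoyl, gives a 3.5-fold higher number from compound 1 to compound 4 (0.55 log units; beyond the scatter) and so moves the number in the direction of weaker inhibition of growth. For the compounds shown here, this is the first change that can be read in one place, and it shows that the group on this nitrogen matters for the result: the isopropyl cannot simply be removed without a shift beyond the usual scatter, even though compound 1 at 8910 nM is itself only a weak inhibitor. Nothing at hand explains why the number rises with this change.

What remains open is whether the isopropyl is a particularly good choice at this nitrogen or merely better than hydrogen, since the compounds shown do not say where a methyl, a cyclopropyl or a longer chain such as n-butyl would fall. They also leave open whether a chain ending in an amine or a carboxylic acid on the same nitrogen would give a lower number than compound 1 does.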